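The compounds below may be only part of what the source reports. "The series", "measured", "known", "first", "only" and "open" are said of these compounds alone.

In a functional assay (muscle tissue) with Rattus norvegicus as the target (on this read-out lower numbers stand for an effect already at smaller amounts and higher numbers for an effect only at larger amounts of compound), the three measured compounds share one core and differ only in the group on an amide-type nitrogen. Compound 1 `CNC(=O)C1=CC(C)(C)Oc2ccc([N+](=O)[O-])cc21` gives 10.7 nM, compound 2 `CCNC(=O)C1=CC(C)(C)Oc2ccc([N+](=O)[O-])cc21` gives 4.57 nM, and compound 3 `CC(C)NC(=O)C1=CC(C)(C)Oc2ccc([N+](=O)[O-])cc21` gives 186 nM, the highest number of the three. Compound 4 `CC1(C)C=C(C(=O)NC2CC2)c2cc([N+](=O)[O-])ccc2O1` has not yet been measured in this assay. It differs from compound 3 by cyclopropyl in place of isopropyl on an amide-type nitrogen, with cyclopropyl in place of isopropyl on an amide-type nitrogen. Two large steps bear on this change, a 17-fold higher number from compound 1 to compound 3 (1.24 log units; beyond the scatter) and a 41-fold higher number from compound 2 to compound 3 (1.61 log units; beyond the scatter), whereas a 2.3-fold lower number from compound 1 to compound 2 (0.37 log units; beyond the scatter) is modest. Within the data shown here, no measured compound carries a ring at this place, so the data test the cyclopropyl group only indirectly. Compound 3 stands apart at 186 nM, so part of that gap is expected to close once isopropyl leaves, though probably not all of it. The expected change is a move to a lower number, a 4.7-fold lower number from compound 3 to compound 4 (0.67 log units; beyond the scatter). For compound 4 the estimate is 40 nM, with an expected range from 10 nM to 160 nM.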

Compound 4, half-maximal effective concentration: 32.4 nM
Compound 4: the middle estimate sits 1.2-fold (0.09 log units) above what was measured, and the stated range covers the measured number.
By their numbers in this assay, from the lowest: compound 2; then compound 1; then compound 4; then compound 3.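

In this assay, cyclopropyl and isopropyl both bring 3 carbon atoms to the amide-type nitrogen, yet the change gives a 5.7-fold lower number from compound 3 to compound 4 (0.76 log units; beyond the scatter), so the carbon count alone does not set the high number of compound 3. The ring does not restore the level of the smaller open chains, since ethyl to cyclopropyl gives a 7.1-fold higher number from compound 2 to compound 4 (0.85 log units; beyond the scatter) and methyl to cyclopropyl gives a 3.0-fold higher number from compound 1 to compound 4 (0.48 log units; beyond the scatter), which places compound 4 between compound 1 and compound 3. No measurement at hand accounts for the difference between the isopropyl and cyclopropyl groups.

As far as these compounds go, it remains open whether a larger ring such as cyclobutyl or cyclopentyl stays near compound 4 or moves toward compound 3. From the compounds shown here alone, a longer chain such as n-propyl or n-butyl on the same nitrogen is equally open, as is a second methyl in place of the amide hydrogen.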